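The source may hold more compounds than are shown below. What is called first, only, known or untested is meant among the compounds shown, and "the series" means these compounds.

Measured compounds in a functional assay on CHO cells with adenosine receptor A1 (Homo sapiens) as the target, read by cAMP accumulation and immunoassay, with a stated time of 6 min, tested at 1 uM; a higher number here means a weaker effect of the compound at the concentration tested, a lower number a stronger effect:
Compound 1 `Nc1scc(CN2CCN(c3ccc(Cl)cc3Cl)CC2)c1C(=O)c1ccc(Cl)cc1` gives -54%.
Compound 2 `Nc1scc(CN2CCN(c3ccccc3F)CC2)c1C(=O)c1ccc(Cl)cc1` gives -9.2%.
Compound 3 `Nc1scc(CN2CCN(c3cccc(F)c3F)CC2)c1C(=O)c1ccc(Cl)cc1` gives -66%.

Compound 3 stands lowest of the three numbers, so its effect is the strongest seen here; the nearest is compound 1, and the gap to compound 2 is far wider. Compound 4 `Nc1scc(CN2CCN(CCCc3ccc(Cl)cc3)CC2)c1C(=O)c1ccc(Cl)cc1` differs from compound 3 in one place: 3-(4-chlorophenyl)propyl in place of 2,3-difluorophenyl on an amine nitrogen in a ring. Among the compounds with values here, no measured step swaps the ring on that nitrogen for a chain; the known steps only alter which halogens that ring carries, and they were a number 44.8 percentage points higher from compound 1 to compound 2 (beyond the scatter), a number 12 percentage points lower from compound 1 to compound 3 (beyond the scatter) and a number 56.8 percentage points lower from compound 2 to compound 3 (beyond the scatter). The group on this nitrogen clearly matters a great deal, but the direction of this new change cannot be read from those steps. For compound 4 a step toward a weaker effect is expected, roughly a number 41 percentage points higher from compound 3 to compound 4 (beyond the scatter), with wide uncertainty. Compound 4 is estimated at -25%, between -75% and 10%.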

Compound 4, a percentage reported as activity, at one concentration (the size of the read-out at that concentration, not a potency): -30%
Beside the measured number, compound 4's estimate is 5 percentage points above it; the measured number falls inside the stated range.
By their numbers in this assay, from the lowest: compound 3; then compound 1; then compound 4; then compound 2.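

In this assay, the 3-(4-chlorophenyl)propyl group shows that a phenyl ring attached directly to the amine nitrogen is not needed for an effect. The change does not act in one direction: there is a number 36 percentage points higher from compound 3 to compound 4 (beyond the scatter) and a number 24 percentage points higher from compound 1 to compound 4 (beyond the scatter) but a number 20.8 percentage points lower from compound 2 to compound 4 (beyond the scatter) for the same chain. The halogens on a directly attached ring therefore decide whether this chain gives a weaker or stronger effect than that ring. Nothing available explains these differences. Open, going by these compounds, is how a shorter ethyl link or a longer butyl link to the same 4-chlorophenyl ring would compare.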